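An Isopropyl Ester Variant of Compound 1

The source may hold more compounds than are shown below. What is called first, only, known or untested is meant among the compounds shown, and "the series" means these compounds.

compound 1, `CCOC(=O)C(=O)Nc1cccccc1=O`: 80%
compound 2, `CCOC(=O)C(=O)Nc1ccccc(O)c1=O`: 5%
compound 3, `CCOC(=O)C(=O)Nc1cccc(OC)cc1=O`: 73%

In a functional assay on the whole organism (strain Sprague-Dawley CD) for inhibition, with Rattus norvegicus as the target, read by paw edema, at a dose of 10 mg/kg by the intraperitoneal route (on this read-out lower numbers stand for a weaker effect and higher numbers for a stronger effect at the one dose given), compound 1 holds the highest of the three numbers. The nearest neighbour is reached by the step of a number 7 percentage points lower from compound 1 to compound 3 (within the scatter), the furthest by the step of a number 75 percentage points lower from compound 1 to compound 2 (beyond the scatter).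

Compound 4, `CC(C)OC(=O)C(=O)Nc1cccccc1=O`, differs from compound 1 by methyl in place of hydrogen on a saturated chain carbon bound to an oxygen next to a carbonyl group and a saturated chain carbon. Among the measured compounds shown here, both measured steps alter an aromatic carbon of the core, not the ester chain, so neither bears directly on this change; they show only that hydroxy moved the number far and methoxy left it within the scatter. For the measured compounds named here, with no measured step on the ester chain, a step within the scatter is expected, a number 6 percentage points lower from compound 1 to compound 4 (within the scatter). Compound 4 is therefore estimated at 74%, with a range from 52% to 90%.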

Compound 4, a percentage reported as inhibition, in the whole organism at one dose (the size of the read-out at that dose, not a potency): 76%
Compound 4: the middle estimate sits 2 percentage points below what was measured; low and high end bracket the measured number.
By their numbers in this assay, from the lowest: compound 2; then compounds 3, 4 and 1 (each within the scatter of the next).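

In this assay, among the compounds shown here, the change from ethyl to isopropyl gives a number 4 percentage points lower from compound 1 to compound 4 (within the scatter), the first measured step on the ester chain rather than on an aromatic carbon of the core. It shows that methyl in place of hydrogen on this saturated chain carbon leaves the number within the scatter at the one dose given. Nothing available explains this result. The compounds shown leave open whether a longer chain such as butyl, or a carboxylic acid in place of the ester, would hold the number. They also leave open how the isopropyl ester behaves alongside hydroxy or methoxy on the aromatic carbon.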